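This account rests on a few compounds, and the source may have more. Where it says the series, first, only, none or still open, it means among the compounds named here.

Compound 3 `C=CC(=O)N1CC(NC(=O)Cn2c(C)c(C(=O)N3CCc4c(cccc4OC)C3)c3cc(Br)ccc32)C1` gives 1.67 h in a physicochemical assay for pharmacokinetics, read by LC-MS, in phosphate buffer, at pH 7.4, in the presence of a further agent that is not named here; on this read-out lower numbers stand for a shorter-lived compound and higher numbers for a longer-lived compound. Compound 1 `C=CC(=O)N1CC(NC(=O)Cn2cc(C(=O)N3CCc4ccccc4C3)c3cc(Br)ccc32)C1` gives 1.67 h in this assay, and compound 2 `C=CC(=O)N1CC(NC(=O)Cn2cc(C(=O)N3CCc4c(F)cccc4C3)c3cc(Br)ccc32)C1` gives 1.67 h, so compound 3 stands level with both at the digits shown, within the scatter. Among the measured compounds shown here, the only single-point step measured, no change at the digits printed from compound 1 to compound 2 (within the scatter), stayed within the scatter. Compound 4 `C=CC(=O)N1CC(NC(=O)Cn2cc(C(=O)N3CCc4c(cccc4OC)C3)c3cc(Br)ccc32)C1` differs from compound 3 by hydrogen in place of methyl on an aromatic carbon, on an aromatic carbon of a five-membered aromatic ring with one nitrogen, next to the ring nitrogen. For the measured compounds named here, no measured step removes a methyl, and the one comparison in hand showed nothing beyond the scatter, so compound 4 is expected to show no step beyond it, no change at the digits printed from compound 3 to compound 4 (within the scatter). The estimate for compound 4 in this assay is 1.67 h, with a range from 0.9 h to 3.3 h.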

Compound 4, half-life: 1.67 h
Compound 4: middle estimate and measured number agree at the digits printed; the range from low to high includes it.
By their numbers in this assay, from the lowest: compounds 1, 2, 3 and 4 (each within the scatter of the next).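

Among the compounds shown here, replacing the methyl on the aromatic carbon next to the ring nitrogen with hydrogen gives no change at the digits printed from compound 3 to compound 4 (within the scatter) in this assay and is the first measured step at this position. Methoxy in place of fluoro gives no change at the digits printed from compound 2 to compound 4 (within the scatter) on an aromatic carbon, and methoxy in place of hydrogen gives no change at the digits printed from compound 1 to compound 4 (within the scatter) on an aromatic carbon, so these changes also stay within the scatter. No measurement here bears on why the half-life holds level. On these data alone, it remains open whether an amine, a carboxylic acid or a longer chain at this position would move the half-life beyond the scatter.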